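Swapping Chloro for Methoxy in a Positive Allosteric Modulator Series

The source may report more compounds than this note shows. Statements on the series, on what has been measured and on what is new or still open speak of the compounds shown alone.

Measured so far:
Compound 1, `Cc1c(OCCCCOc2ccc(Cl)c(C(=O)O)c2)ccc(C(=O)CC(C)(C)C)c1O`, gives 130 nM.
Compound 2, `COc1ccc(OCCCCOc2ccc(C(=O)CC(C)(C)C)c(O)c2C)cc1C(=O)O`, gives 490 nM.
Compound 3, `Cc1c(OC[C@@H](C)COc2ccc(C(=O)O)c(Cl)c2)ccc(C(=O)CC(C)(C)C)c1O`, gives 860 nM.

These values come from an assay for positive allosteric modulation of metabotropic glutamate receptor 3 (Rattus norvegicus); on this read-out higher numbers stand for an effect only at larger amounts of compound and lower numbers for an effect already at smaller amounts. Going from compound 1 to compound 2 the change is methoxy in place of chloro on an aromatic carbon, and it gave a 3.8-fold higher number from compound 1 to compound 2 (0.58 log units; beyond the scatter). The cores of compound 1 and compound 3 contain the same atoms joined differently, and the difference between the two cores is not broken down here. Compound 4, `COc1cc(OC[C@H](C)COc2ccc(C(=O)CC(C)(C)C)c(O)c2C)ccc1C(=O)O`, is still unmeasured; it differs from compound 3 by methoxy in place of chloro on an aromatic carbon. This is the same kind of change as from compound 1 to compound 2, but the place is not identical: in compound 2 the methoxy sits para to a large group, in compound 4 meta to it. Resting on the step from compound 1 to compound 2, a smaller shift of the same sign is expected for compound 4, estimated as a 2.9-fold higher number from compound 3 to compound 4 (0.46 log units; beyond the scatter). Compound 4 is therefore expected to give about 2500 nM in this assay, with a plausible range from 900 nM to 8000 nM.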

Compound 4, half-maximal effective concentration: 1460 nM
For compound 4 the middle estimate is 1.7-fold (0.23 log units) above the measured one, and the stated range covers the measured number.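

In this assay, methoxy in place of chloro gave a 1.7-fold higher number from compound 3 to compound 4 (0.23 log units; within the scatter), so on this core the two numbers cannot be told apart. Set beside the earlier case, the two steps do not differ by more than the usual scatter: the same change on two cores in this assay, a 3.8-fold higher number (0.58 log units; beyond the scatter) from compound 1 to compound 2 and a 1.7-fold higher number (0.23 log units; within the scatter) from compound 3 to compound 4, 2.2-fold (0.35 log units) apart, within the scatter of two such steps. This is compatible with the change carrying over from one core to the other, but two pairs, with the methoxy not in an identical place, cannot show that it holds generally or predict its size on a further core.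

As far as these compounds go, it remains open whether an amine or a methyl group in place of the chloro would behave like methoxy. From the compounds shown here alone, the effect of a longer chain on this swap is also open.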